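The compounds below may be only part of what the source reports. "The series", "measured", "known", "first", "only" and "open" are said of these compounds alone.

Working notes on the series. Compound 3 `CCc1ccc(Nc2cc(NC(=O)Nc3cc(OC)cc(OC)c3)ncn2)cc1` gives 23.5% in a functional assay on NCI-H520 cells (Homo sapiens) for inhibition, read by MTT assay, with a stated time of 48 h, tested at 10 uM; on this read-out lower numbers stand for less inhibition and higher numbers for more inhibition at the one concentration tested (going by the name of the read-out). Among the three measured compounds it holds the lowest number: compound 2 `COc1cc(NC(=O)Nc2cc(Nc3ccc(C)c(F)c3)ncn2)cc(OC)c1` gives 30.6%, a gap within the scatter, and compound 1 `COc1cc(NC(=O)Nc2cc(Nc3cc(Br)ccc3OC)ncn2)cc(OC)c1` gives 43.5%, a gap beyond the scatter. The step of a number 7.1 percentage points lower from compound 2 to compound 3 (within the scatter) is thus within the scatter, while a number 20 percentage points lower from compound 1 to compound 3 (beyond the scatter) and a number 12.9 percentage points lower from compound 1 to compound 2 (beyond the scatter) are modest and beyond it.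

Compound 4 `COc1cc(NC(=O)Nc2cc(Nc3ccc(C)c(C)c3)ncn2)cc(OC)c1` is not yet measured. Its difference from compound 3 is 3,4-dimethylphenyl in place of 4-ethylphenyl on a nitrogen on an aromatic ring. Every measured step in the series is a swap of the group on that same nitrogen, and the one that most resembles this swap, a number 7.1 percentage points lower from compound 2 to compound 3 (within the scatter), stays within the scatter; the two larger steps both involve the 5-bromo-2-methoxyphenyl group of compound 1, which is not in play here. The expectation for this assay is therefore a step of a number 2.5 percentage points higher from compound 3 to compound 4 (within the scatter), no more than the scatter, in either direction. Compound 4 is estimated at 26%, expected between 14% and 40%.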

Compound 4, a percentage reported as inhibition, at one concentration (the size of the read-out at that concentration, not a potency): 29.5%
Compound 4: middle estimate off by 3.5 percentage points, on the low side; the measured number falls inside the stated range.
By their numbers in this assay, from the lowest: compounds 3, 4 and 2 (each within the scatter of the next); then compound 1.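

Working from this assay, the same eight carbons arranged as 3,4-dimethylphenyl rather than 4-ethylphenyl on the nitrogen give a number 6 percentage points higher from compound 3 to compound 4 (within the scatter), so this rearrangement of the carbon atoms does not separate the two compounds. Methyl in place of fluoro on an aromatic carbon gives a number 1.1 percentage points lower from compound 2 to compound 4 (within the scatter), which places compound 2, compound 3 and compound 4 together, while a number 14 percentage points lower from compound 1 to compound 4 (beyond the scatter) leaves compound 1 as the only compound set apart from the others beyond the scatter. No measured evidence is at hand to account for any of these steps.

Open is whether the number of compound 1 goes with the bromo or the methoxy group of its 5-bromo-2-methoxyphenyl, as each appears among the compounds shown only with the other. Also open, as far as these compounds go, is how a carboxylic acid or an amine on this phenyl ring would read in this assay.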